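The source may report more compounds than this note shows. Statements on the series, on what has been measured and on what is new or still open speak of the compounds shown alone.

Of the compounds shown here, two with a shared core have been measured so far. Compound 1 `COc1nn2cc(-c3cc4c(OC)ccc(OC)c4o3)nc2s1` and compound 2 `COc1nn2cc(-c3cc4ccccc4o3)nc2s1` differ in the groups carried on the fused two-ring portion attached to the core. In an assay on a cell-free system (plasma) for antagonist activity at proteinase-activated receptor 4 (Homo sapiens), with a stated time of 5 min, in the presence of a further agent that is not named here (a lower number here means a stronger inhibitor, a higher number a weaker inhibitor), compound 1 gives 10000 nM, and in the same this assay compound 2 gives 15000 nM; these two numbers lie within the usual scatter of each other, so nothing separates them beyond repeated-measurement noise. Compound 3 `COc1nn2cc(-c3cc4cccc(OC)c4o3)nc2s1` has not yet been measured. Compared with compound 2, the change is methoxy in place of hydrogen on an aromatic carbon, placed on an aromatic carbon of a six-membered aromatic ring of carbon only, part of a fused or bridged system of two rings, ortho to a fused ring and meta to a fused ring. Going by the values given here, no step between measured compounds is known for such a change, so there is no basis for expecting a shift in either direction beyond the scatter. On that basis the step from compound 2 to compound 3 in this assay is estimated at a 1.3-fold lower number from compound 2 to compound 3 (0.10 log units; within the scatter). Compound 3 is therefore expected to give about 12000 nM in this assay, most likely somewhere between 5000 nM and 30000 nM.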

Compound 3, half-maximal inhibitory concentration: 3500 nM
Beside the measured number, compound 3's estimate is 3.4-fold (0.54 log units) above it; the whole stated range lies above it.
By their numbers in this assay, from the lowest: compound 3; then compounds 1 and 2 (each within the scatter of the next).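

In this assay, methoxy in place of hydrogen on this aromatic carbon, ortho to a fused ring and meta to a fused ring, gives a 4.3-fold lower number from compound 2 to compound 3 (0.63 log units; beyond the scatter), a modest step but one beyond the scatter, so this position does respond to substitution. Going by these compounds alone, compound 1 carries the same methoxy together with a second one on the six-membered ring, and replacing that second methoxy with hydrogen gives a 2.9-fold lower number from compound 1 to compound 3 (0.46 log units; beyond the scatter), so the lower number appears with the single methoxy of compound 3 but not when both groups are present, as compound 1 and compound 2 lie within the scatter of each other. No measurement shown here gives a reason for either step.

From the compounds shown here alone, it remains open whether the gain belongs to methoxy itself or would also come with another group on the same carbon, such as a hydroxyl, a fluorine, an amine or the longer ethoxy. Going by these compounds, it is also open how far this position can take the number down, since compound 3 still stands at 3500 nM, and whether a different group in place of the second methoxy of compound 1 would keep the gain.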